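A few compounds are considered here, and "the series" means these few. Any claim that something is new, unique, unknown or untested is made for them only; others in the source may bear on it.

Measured so far in a functional assay on NCI-H460 cells (Homo sapiens) for cytotoxicity, read by MTT assay, with a stated time of 72 h; on this read-out higher numbers stand for weaker inhibition and lower numbers for stronger inhibition:
compound 1 `CN(C)Cc1ccc2nc(NC(=O)N/N=C/c3cn(Cc4ccccc4Cl)c4ccccc34)sc2c1` gives 1600 nM
compound 2 `CC1CCN(Cc2ccc3nc(NC(=O)N/N=C/c4cn(Cc5ccc(Cl)cc5Cl)c5ccccc45)sc3c2)CC1` gives 1660 nM

The two values lie within the scatter of each other, and on these numbers compound 2 stands level with compound 1. For the measured compounds named here, the two compounds differ in more than one place, and no measured step isolates a single group.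

Still unmeasured is compound 3 `CC1CCN(Cc2ccc3nc(NC(=O)N/N=C/c4cn(Cc5cccc(Cl)c5)c5ccccc45)sc3c2)CC1` and it differs from compound 2 in one place, on a saturated chain carbon bound to an aromatic nitrogen: 3-chlorophenyl in place of 2,4-dichlorophenyl on a saturated chain carbon bound to an aromatic nitrogen (the same difference reads 2,4-dichlorobenzyl to 3-chlorobenzyl) and the rest of the structure is shared.

Going by the values given here, the data hold no measured step of this kind, and the evidence for any expectation is thin. Among the compounds with values here, the only guide is that compound 1 at 1600 nM and compound 2 at 1660 nM sit within the scatter despite their differences. In this assay no step beyond the scatter is expected, in either direction. The estimate amounts to an expected 1.1-fold lower number from compound 2 to compound 3 (0.04 log units; within the scatter) on this evidence. For compound 3 the expected value is 1500 nM with an estimated range from 600 nM to 3600 nM for now.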

Compound 3, half-maximal inhibitory concentration: 280 nM
Beside the measured number, compound 3's estimate is 5.4-fold (0.73 log units) above it; measured number below the stated range.
By their numbers in this assay, from the lowest: compound 3; then compounds 1 and 2 (each within the scatter of the next).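

Read in this assay the substituent on the saturated chain carbon bound to an aromatic nitrogen proves able to shift the number: going from 2,4-dichlorobenzyl to 3-chlorobenzyl gives a 5.9-fold lower number from compound 2 to compound 3 (0.77 log units; beyond the scatter) and is the first step in the series that isolates one place. The level values of the earlier pair could not show this, as those two compounds differ in more than one place and their agreement said nothing about this position alone. The change keeps the six-membered aromatic ring of carbon, adds no hydrogen-bond donor, acceptor or net charge, and takes the group from 8 heavy atoms to 7 with one chlorine fewer, but no measurement at hand explains the lower number.

For the compounds shown here, the single step changes both the number of chlorines and their placement on the ring, so it cannot say which of the two carries the effect; 4-chlorophenyl or unsubstituted phenyl on the same carbon, with the rest of the structure kept, would help to separate them. On these data alone, whether another halogen, such as 3-bromophenyl or 3-fluorophenyl, behaves like 3-chlorophenyl also remains open.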